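A Benzyl Group Replaces an Aryl on Sulfur

This account rests on a few compounds, and the source may have more. Where it says the series, first, only, none or still open, it means among the compounds named here.

Of the compounds shown here, three have been tested in a functional assay on DU-145 cells (Homo sapiens) for inhibition, read by trypan blue exclusion, with a stated time of 96 h; a higher number here means a weaker inhibitor of growth, a lower number a stronger inhibitor of growth. Compound 1 `O=C(/C(=C\c1ccc(O)c([N+](=O)[O-])c1)SCc1ccc(Br)cc1)c1c(F)c(F)c(F)c(F)c1F` gives 10000 nM in this assay. Compound 2 `O=C(/C(=C\c1ccc(Cl)cc1)Sc1ccc(Cl)cc1)c1ccc(Cl)cc1` gives 1000 nM, the lowest number of the three and therefore the strongest inhibitor of growth among them, with compound 1 and compound 3 both beyond the usual scatter. Compound 3 `O=C(/C(=C\c1c(O)cc(O)cc1O)Sc1ccc(Br)cc1)c1ccc(Cl)cc1` gives 50000 nM, the weakest of the set.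

The next compound, compound 4 `Cc1ccc(CS/C(=C/c2ccc(Cl)cc2)C(=O)c2ccc(Cl)cc2)cc1`, differs from compound 2 in one place: 4-methylbenzyl in place of 4-chlorophenyl on a sulfur. Going by the values given here, no measured pair shows this exact change on an otherwise identical framework, so its effect cannot be read off directly. Among the compounds with values here, the only other compound with a benzyl group on sulfur, compound 1, carries a different ring on the double-bonded carbon and a different ketone aryl as well, so its higher number cannot be tied to the sulfur group alone.

A modest loss of growth inhibition is expected, and the step of a 2.5-fold higher number from compound 2 to compound 4 (0.40 log units; beyond the scatter) is estimated to lie just beyond the scatter. Compound 4 is therefore expected to give about 2500 nM in this assay, within a range from 600 nM to 10000 nM.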

Compound 4, concentration for 50% growth inhibition: 10000 nM
The estimate for compound 4 lay 4.0-fold (0.60 log units) below the measured number; the measured number falls inside the stated range.
By their numbers in this assay, from the lowest: compound 2; then compounds 1 and 4 (each within the scatter of the next); then compound 3.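

Going by these compounds alone, this is the first reading of a change at this sulfur with the rest of the framework held constant: 4-methylbenzyl in place of 4-chlorophenyl gives a 10-fold higher number from compound 2 to compound 4 (1.00 log units; beyond the scatter) in this assay. The group on this sulfur therefore influences growth inhibition on this framework, and 4-chlorophenyl is the better of the two groups compared here. Nothing among the data shown accounts for this loss.

The change alters two features at once, adding a carbon between the sulfur and the ring and replacing chlorine on the ring with methyl, and the compounds shown do not separate their contributions. A 4-chlorobenzyl or 4-methylphenyl group on this sulfur would pull those two features apart, while an amine or a carboxylic acid on that ring remains an open case.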